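Removing one trifluoromethyl group across two cores

The source may report more compounds than this note shows. Statements on the series, on what has been measured and on what is new or still open speak of the compounds shown alone.

The set rests on two cores. Compound 2 `FC(F)(F)c1cc(/C=C\c2cc3ccccc3nc2Cl)cc(C(F)(F)F)c1` and compound 1 `FC(F)(F)c1cccc(/C=C\c2cc3ccccc3nc2Cl)c1` share the first; compound 3 `COc1ccc2nc(Cl)c(/C=C\c3ccc(C(F)(F)F)cc3C(F)(F)F)cc2c1` and the not yet measured compound 4 `COc1ccc2nc(Cl)c(/C=C\c3ccccc3C(F)(F)F)cc2c1` share the second, and the difference between the two cores is not broken down here.

In a functional assay on MDA-MB-231 cells (Homo sapiens) for antiproliferative activity, read by sulforhodamine B assay, with a stated time of 72 h (on this read-out higher numbers stand for weaker inhibition and lower numbers for stronger inhibition), compound 2 gives 10100 nM, and compound 1 gives 3750 nM. The change that separates them is hydrogen in place of trifluoromethyl on an aromatic carbon and it brought a 2.7-fold lower number from compound 2 to compound 1 (0.43 log units; beyond the scatter).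

Compound 3 reaches only a limit of the assay: in this assay compound 3 gives > 50000 nM, that is, (the limit of > 50000 nM in this assay, at which 1 of the 3 values shown sits).

Compound 4 arises from compound 3 by hydrogen in place of trifluoromethyl on an aromatic carbon. Within the data shown here, this is the same kind of change as the one from compound 2 to compound 1, but not the same: in compound 2 the departing group sits meta to a large group and meta to a trifluoromethyl group, whereas in compound 3 it sits meta to a trifluoromethyl group and para to a large group.

Taking the measured step as the guide, the expected step for compound 4 is an at least 1.6-fold lower number from compound 3 to compound 4 (0.22 log units; that floor lies within the scatter), resting on a 2.7-fold lower number from compound 2 to compound 1 (0.43 log units; beyond the scatter). Because compound 3 gives only a limit, > 50000 nM, the starting point is not fixed, and compound 4 may itself return only a limit. Compound 4 in this assay is estimated at 30000 nM, with a likely range from 8000 nM to 100000 nM.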

Compound 4, half-maximal inhibitory concentration: 2770 nM
Estimate against measurement, compound 4: 11-fold (1.03 log units) above, and the stated range ends above it.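

Hydrogen in place of trifluoromethyl on an aromatic carbon brought, in this assay, an at least 18-fold lower number from compound 3 to compound 4 (1.25 log units; beyond the scatter), so the number fell on both cores, but the size of the step did not carry over from one core to the other: the same change on two cores in this assay, a 2.7-fold lower number (0.43 log units; beyond the scatter) from compound 2 to compound 1 and an at least 18-fold lower number (1.25 log units; beyond the scatter) from compound 3 to compound 4, at least 6.7-fold (0.82 log units) apart, beyond the scatter of two such steps

The reading of compound 3 is a limit of the assay and not a number: the limit of > 50000 nM in this assay, at which 1 of the 4 values shown sits.

The two pairs show only that the direction held in both cases and that a step measured on one core is a poor guide to the size of the step on the other; they do not show what sets the gap, as the cores differ and the departing trifluoromethyl group also stands in a different place on the ring in each pair, and these two differences cannot be separated with two pairs.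

Open, as far as these compounds go, is how the removal behaves when the departing group stands in the same place on both cores, which would isolate the contribution of the core. Also open, from the compounds shown here alone, is whether a replacement other than hydrogen, such as a nitrile or an amine in the place of the trifluoromethyl group, would follow either step.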